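Ester to Acid: Cytotoxicity Expectation for Compound 4

The source may report more compounds than this note shows. Statements on the series, on what has been measured and on what is new or still open speak of the compounds shown alone.

Compound 1 `NC(=O)c1sc2nc(-c3ccccc3)cc(C(F)(F)F)c2c1N`: in an ADME assay on Huh-7 cells (Homo sapiens) for cytotoxicity, read by MTT assay, with a stated time of 72 h (a lower number here means that less compound is tolerated, a higher number that more compound is tolerated), compound 1 gives > 20000 nM, a limit of the assay.
Compound 2 `CCOC(=O)c1sc2nc(-c3ccccc3)cc(C(F)(F)F)c2c1N`: in this assay compound 2 gives > 20000 nM, a limit of the assay.
Compound 3 `CCOC(=O)c1sc2nc(C3CC3)cc(C(F)(F)F)c2c1N`: in this assay compound 3 gives > 20000 nM, a limit of the assay.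

Compound 2 stands at the limit of the assay, as do the two other measured compounds: the limit of > 20000 nM in this assay, at which 3 of the 3 values shown sit. Neither measured step gives a readable size. The step from the carboxamide to the ester, a step that the two limits leave unreadable from compound 1 to compound 2, and the step from phenyl to cyclopropyl, a step that the two limits leave unreadable from compound 2 to compound 3, both run between two limits.

Compound 4 `Nc1c(C(=O)O)sc2nc(-c3ccccc3)cc(C(F)(F)F)c12` differs from compound 2 in one place: hydrogen in place of ethyl on an oxygen next to a carbonyl group. Going by the values given here, no measured step bears directly on this change, and the steps that have been measured, a step that the two limits leave unreadable from compound 1 to compound 2 and a step that the two limits leave unreadable from compound 2 to compound 3, show only that no readable move away from the limit occurred across the three measured compounds. In this assay no step beyond the scatter is therefore expected, and the estimated step that the limit leaves unreadable from compound 2 to compound 4 is taken as no readable change. Compound 4 is expected to give 30000 nM in this assay, within a range from 15000 nM to 100000 nM, most likely reported again only as a limit.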

Compound 4, half-maximal cytotoxic concentration: > 20000 nM
Compound 4 ended at the assay's limit; the forecaster's own chance of this, stated with the estimate: 85%; the middle value is on the limit's open side.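

In this assay compound 4 gives > 20000 nM, a limit of the assay, so its steps from compound 1 and compound 2 cannot be read. All the compounds share one limit: the limit of > 20000 nM in this assay, at which 4 of the 4 values shown sit.

The compounds shown leave open how far each lies beyond that limit, and so whether hydrogen in place of ethyl changes the tolerated concentration at all.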